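Swapping Bromine for Chlorine on the Anilide Ring

The source may hold more compounds than are shown below. What is called first, only, known or untested is meant among the compounds shown, and "the series" means these compounds.

Among the compounds with values here, compound 2 `N#Cc1cccc([C@]23CCC(N(CCN4CC[C@@H](O)C4)C(=O)Nc4cccc(Br)c4)CC2C3)c1` gives 34 nM in a functional assay for antagonist activity at melanin-concentrating hormone receptor 1 (Homo sapiens) (a higher number here means a weaker inhibitor, a lower number a stronger inhibitor), the lower of the two numbers measured so far, while compound 1 `N#Cc1cccc([C@]23CCC(N(CCN4CC[C@@H](O)C4)C(=O)Nc4ccccc4)CC2C3)c1` gives 132 nM. Within the data shown here, the only measured step, a 3.9-fold lower number from compound 1 to compound 2 (0.59 log units; beyond the scatter), bears on the new compound only indirectly, as it shows what a halogen on that aromatic carbon brings relative to hydrogen. Compound 3 `N#Cc1cccc([C@]23CCC(N(CCN4CC[C@@H](O)C4)C(=O)Nc4cccc(Cl)c4)CC2C3)c1` differs from compound 2 by chloro in place of bromo on an aromatic carbon. Since a halogen remains, the expected step in this assay is small, with no direction beyond the scatter. The estimate for compound 3 is 45 nM, within 20 nM to 100 nM, which means a 1.3-fold higher number from compound 2 to compound 3 (0.12 log units; within the scatter).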

Compound 3, inhibition constant: 27 nM
Estimate against measurement, compound 3: 1.7-fold (0.22 log units) above; the measured number falls inside the stated range.
By their numbers in this assay, from the lowest: compounds 3 and 2 (each within the scatter of the next); then compound 1.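

In this assay, the step from bromo to chloro (a 1.3-fold lower number from compound 2 to compound 3 (0.10 log units; within the scatter)) stays within the scatter, so the two halogens cannot be told apart at this position. The step from hydrogen to chloro (a 4.9-fold lower number from compound 1 to compound 3 (0.69 log units; beyond the scatter)) shows that the gain seen with bromo is not confined to that one halogen. No evidence here explains this shared gain. The compounds shown leave open whether a methoxy group or an amine on the same aromatic carbon would match either halogen, and whether fluoro would follow chloro and bromo.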